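Removing One Methyl From Compound 1

The source may hold more compounds than are shown below. What is called first, only, known or untested is meant among the compounds shown, and "the series" means these compounds.

Compound 1 `CCC(C)(C)c1ccc(OCCCCN2CCN(c3cccnc3)CC2)cc1`: 3.23 nM
Compound 2 `CCC(C)(C)c1ccc(OCCCCN2CCN(c3cnccn3)CC2)cc1`: 9.56 nM
Compound 3 `CCC(C)(C)c1ccc(OCCCCN2CCN(c3ncccn3)CC2)cc1`: 17.7 nM

In a functional assay on L5178Y cells (Mus musculus) for antiproliferative activity, read by MTT assay (a lower number here means a stronger inhibitor, a higher number a weaker inhibitor), compound 1 has the lowest number of these three, and its steps to the other two lie beyond the scatter. Compound 4 `CC(C)(C)c1ccc(OCCCCN2CCN(c3cccnc3)CC2)cc1` differs from it in one place: hydrogen in place of methyl on a saturated chain carbon, two bonds along the chain from an aromatic carbon. Thus 1,1-dimethylpropyl becomes tert-butyl. Among the compounds with values here, no measured step touches this place. Within the data shown here, the only guides are swaps of the ring on an amine nitrogen, a 3.0-fold higher number from compound 1 to compound 2 (0.47 log units; beyond the scatter) and a 5.5-fold higher number from compound 1 to compound 3 (0.74 log units; beyond the scatter), both modest, and a 1.9-fold higher number from compound 2 to compound 3 (0.27 log units; within the scatter), within the scatter. They suggest only how far one change can move these numbers, not the direction. A small step, perhaps none beyond the scatter, is therefore expected. The expected change is a 1.4-fold higher number from compound 1 to compound 4 (0.14 log units; within the scatter). For compound 4 the estimate is 4.5 nM, with an expected range of 1.5 nM to 13 nM.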

Compound 4, half-maximal inhibitory concentration: 5.48 nM
Compound 4: the middle estimate sits 1.2-fold (0.09 log units) below what was measured, within the range that was stated.
By their numbers in this assay, from the lowest: compounds 1, 4, 2 and 3 (each within the scatter of the next, the first and the last beyond it).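

In this assay, trimming 1,1-dimethylpropyl to tert-butyl gives a 1.7-fold higher number from compound 1 to compound 4 (0.23 log units; within the scatter), the first step measured at this place. The methyl on this saturated chain carbon can therefore go without a change beyond the scatter, so this one carbon is not needed to keep the number in the same range. Nothing measured here explains this result. Still open, from the compounds shown here alone, is what a hydroxyl, an amine or a longer chain at this place would do. Also open, going by these compounds, is whether pyrazin-2-yl or pyrimidin-2-yl would shift the number on the tert-butyl compound as they do on compound 1.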